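The source may hold more compounds than are shown below. What is called first, only, known or untested is meant among the compounds shown, and "the series" means these compounds.

In an ADME assay on HEK293 cells (Homo sapiens) for cytotoxicity, read by MTT assay, with a stated time of 48 h (on this read-out higher numbers stand for weaker inhibition and lower numbers for stronger inhibition), two compounds sharing one core have been measured so far. Compound 1 `CCCn1c(N)c(-c2nc3ccccc3[nH]2)c2nc(C#N)c(C#N)nc21` gives > 50000 nM, which is a limit of the assay. Among the compounds with values here, compound 2 `CN(C)CCCn1c(N)c(-c2nc3ccccc3[nH]2)c2nc(C#N)c(C#N)nc21` gives 8360 nM, the only actual number. Compound 3 `N#Cc1nc2c(-c3nc4ccccc4[nH]3)c(N)n(CCCO)c2nc1C#N` differs from compound 2 by hydroxy in place of dimethylamino on a saturated chain carbon, three bonds along the chain from an aromatic nitrogen, turning 3-(dimethylamino)propyl into 3-hydroxypropyl. Within the data shown here, the one measured step bearing on this is an at least 5.9-fold lower number from compound 1 to compound 2 (0.77 log units; beyond the scatter), made by dimethylamino in place of hydrogen at that same place. Its size is only a bound, set by the limit of > 50000 nM in this assay, at which 1 of the 2 values shown sits. With dimethylamino gone again, a partial return towards the higher number of compound 1 at > 50000 nM is expected. The expected step is a 3.6-fold higher number from compound 2 to compound 3 (0.55 log units; beyond the scatter), similar to or somewhat smaller than the measured one. For compound 3 the estimate is 30000 nM, with an expected range from 12000 nM to 75000 nM.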

Compound 3, half-maximal inhibitory concentration: > 50000 nM
Compound 3: only a limit was reported; the forecaster's own chance of this, stated with the estimate: 45%; at least 1.6-fold (0.22 log units) between middle value and limit.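

In this assay, hydroxy in place of dimethylamino on a saturated chain carbon, three bonds along the chain from an aromatic nitrogen, gives an at least 5.9-fold higher number from compound 2 to compound 3 (0.77 log units; beyond the scatter), so the lower number of compound 2 does not carry over to this second group at the same place. Compound 3 gives > 50000 nM, which is a limit of the assay, and the step that joins it to compound 1 cannot be read. The size of the step to compound 3 remains only a bound, because the read-out gives no number there: the limit of > 50000 nM in this assay, at which 2 of the 3 values shown sit.

As far as these compounds go, it remains open whether the lower number goes with dimethylamino alone or would also appear with a primary amine, a pyrrolidine or a morpholine at this place. A longer chain carrying dimethylamino is also untested among the compounds shown, so the bearing of chain length on this read-out remains unknown.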